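The compounds below may be only part of what the source reports. "The series", "measured", "known", "first", "only" and "open" are said of these compounds alone.

Working notes on the shared core, an azetidinone bearing a trimethoxyphenyl on nitrogen and a para-substituted phenyl on the ring carbon. In a functional assay on HL-60 cells (Homo sapiens) for inhibition, read by resazurin assay, with a stated time of 72 h (a higher number here means a weaker inhibitor, a lower number a stronger inhibitor), compound 1 `COc1ccc(C2C(O)C(=O)N2c2cc(OC)c(OC)c(OC)c2)cc1` gives 13 nM; compound 2 `CCSc1ccc(C2CC(=O)N2c2cc(OC)c(OC)c(OC)c2)cc1` gives 204 nM; compound 3 `CCOc1ccc(C2CC(=O)N2c2cc(OC)c(OC)c(OC)c2)cc1` gives 88 nM. Compound 3 thus stands second highest of the three numbers, nearest to compound 2 and furthest from compound 1, which differs from it in more than one place and is set aside here. Going by the values given here, the only single-point step so far, a 2.3-fold lower number from compound 2 to compound 3 (0.37 log units; beyond the scatter), is a modest one and concerns the heteroatom, not the length of the chain.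

Compound 4 `COc1ccc(C2CC(=O)N2c2cc(OC)c(OC)c(OC)c2)cc1` is reached from compound 3 by hydrogen in place of methyl on a saturated chain carbon bound to an oxygen on an aromatic ring. Among the compounds with values here, no measured step trims a chain, so the exchange of ethoxy for methoxy has no direct precedent; the measured step on this position is of a different kind and offers no direction. A step within the usual scatter is therefore expected, a 1.3-fold lower number from compound 3 to compound 4 (0.10 log units; within the scatter), and compound 4 is estimated at 70 nM in this assay, between 25 nM and 200 nM.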

Compound 4, half-maximal inhibitory concentration: 76 nM
Beside the measured number, compound 4's estimate is 1.1-fold (0.04 log units) below it, within the range that was stated.
By their numbers in this assay, from the lowest: compound 1; then compounds 4 and 3 (each within the scatter of the next); then compound 2.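

In this assay, shortening ethoxy to methoxy leaves the number within the scatter (a 1.2-fold lower number from compound 3 to compound 4 (0.06 log units; within the scatter)), so on this aromatic substituent the change from ethyl to methyl shows no measurable effect. Going by these compounds alone, the oxygen-for-sulfur difference seen with the ethyl chain also appears with a shorter chain, as methoxy in place of ethylsulfanyl gives a modest step beyond the scatter (a 2.7-fold lower number from compound 2 to compound 4 (0.43 log units; beyond the scatter)), while the first reading of the saturated ring carbon shows that hydrogen in place of hydroxy also gives a modest step beyond the scatter (a 5.8-fold higher number from compound 1 to compound 4 (0.77 log units; beyond the scatter)). No measurement at hand explains any of these steps.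

As far as these compounds go, whether a longer chain such as propoxy would stay within the scatter remains open. Also open, from the compounds shown here alone, is whether hydroxy on the saturated ring carbon would give a similar step alongside ethoxy or ethylsulfanyl, or whether an amine there would match it.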